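Octyl in Place of a Substituted Phenyl in Compound 2

The source may report more compounds than this note shows. Statements on the series, on what has been measured and on what is new or still open speak of the compounds shown alone.

Measured so far in a functional assay on IMR-32 cells (Homo sapiens) for antiproliferative activity, read by MTT assay; a lower number here means a stronger inhibitor, a higher number a weaker inhibitor:
- compound 1 `CC1(C)CCc2cc(C(=O)/C=C/c3ccc(OCc4cn(-c5ccc(Cl)cc5)nn4)cc3)c(O)cc2O1`: 92100 nM
- compound 2 `Cc1c(-n2cc(COc3ccc(/C=C/C(=O)c4ccc5c(c4O)CCC(C)(C)O5)cc3)nn2)cccc1[N+](=O)[O-]`: 73500 nM
- compound 3 `CCCCCCCCn1cc(COc2ccc(/C=C/C(=O)c3cc4c(cc3O)OC(C)(C)CC4)cc2)nn1`: 7090 nM

In this assay, compound 2 at 73500 nM lies within the usual scatter of compound 1 at 92100 nM. Compound 3, at 7090 nM, gives a much lower number than compound 2, a gap beyond the scatter.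

Compound 4 `CCCCCCCCn1cc(COc2ccc(/C=C/C(=O)c3ccc4c(c3O)CCC(C)(C)O4)cc2)nn1` has not been measured yet. It keeps the core of compound 2 and changes one group: octyl in place of 2-methyl-3-nitrophenyl on an aromatic nitrogen. In words, this is octyl in place of 2-methyl-3-nitrophenyl on an aromatic nitrogen.

For the measured compounds named here, one measured step bears on this change. Going a 13-fold lower number from compound 1 to compound 3 (1.11 log units; beyond the scatter), octyl also took the place of a substituted phenyl on an aromatic nitrogen, and the step was large. Going by the values given here, it is only a partial guide, since the core of compound 1 differs from the core of compound 2, the departing phenyl groups differ too, and this is the only such step measured. A drop of similar size is still the best expectation. In this assay the expected step is an 11-fold lower number from compound 2 to compound 4 (1.02 log units; beyond the scatter), towards a stronger inhibitor and beyond the scatter. The estimate for compound 4 is 7000 nM, with an expected range of 2500 nM to 20000 nM.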

Compound 4, half-maximal inhibitory concentration: "not active" (no number reported)
For compound 4 the study gives words and no number, and the estimate cannot be compared.
By their numbers in this assay, from the lowest: compound 3; then compounds 2 and 1 (each within the scatter of the next).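

In this assay, for the compounds shown here, compound 4 is reported only in words, as "not active", so no step from compound 2 to compound 4 can be read. The compounds shown leave open whether the drop seen in a 13-fold lower number from compound 1 to compound 3 (1.11 log units; beyond the scatter) carries over to the core of compound 2. Nothing given here explains the result.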